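The source may report more compounds than this note shows. Statements on the series, on what has been measured and on what is new or still open speak of the compounds shown alone.

Measured compounds in a functional assay on HT-29 cells (Homo sapiens) for cytotoxicity, read by sulforhodamine B assay; a lower number here means a stronger inhibitor, a higher number a weaker inhibitor:
- compound 1, `C=C1[C@@H](OC(C)=O)C[C@@H]2[C@](C)(COC=O)[C@H](OC(C)=O)CC[C@@]2(C)[C@@H]1C[C@@H](Nc1cccc(F)c1)C1=CCOC1=O`: 9410 nM
- compound 2, `C=C1[C@@H](OC(C)=O)C[C@@H]2[C@](C)(CO[Si](C)(C)C(C)(C)C)[C@H](OC(C)=O)CC[C@@]2(C)[C@@H]1C[C@@H](Nc1cccc(F)c1)C1=CCOC1=O`: 4520 nM
- compound 3, `C=C1[C@@H](C/C=C2/C(=O)OC[C@H]2OC(C)=O)[C@]2(C)CC[C@@H](OC(C)=O)[C@@](C)(CO[Si](C)(C)C(C)(C)C)[C@H]2C[C@@H]1O`: 9310 nM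

Compound 1 gives the highest of the three numbers in this assay; compound 3 lies within the scatter of it, and compound 2 is the only one separated from it, by a 2.1-fold lower number from compound 1 to compound 2 (0.32 log units; beyond the scatter). That step concerns a silyl group in place of a formate on an oxygen on a saturated carbon and has nothing to do with the aniline part of the shared core.

Compound 4, `C=C1[C@@H](OC(C)=O)C[C@@H]2[C@](C)(COC=O)[C@H](OC(C)=O)CC[C@@]2(C)[C@@H]1C[C@@H](Nc1ccc(C(=O)O)cc1)C1=CCOC1=O`, differs from compound 1 only at the amine nitrogen: 4-carboxyphenyl in place of 3-fluorophenyl on an amine nitrogen. For the measured compounds named here, none of the measured steps touches this position, and no other pair among compounds 1 to 3 varies the aryl group on the nitrogen, so there is no measured precedent for the size or direction of the step. With nothing to go on beyond the value of compound 1, the expectation for compound 4 in this assay is a number close to that of compound 1, with a wide range around it, and the expected step of a 1.1-fold higher number from compound 1 to compound 4 (0.03 log units; within the scatter) is taken as lying within the scatter. Compound 4 is accordingly estimated at 10000 nM, between 3000 nM and 35000 nM.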

Compound 4, half-maximal inhibitory concentration: 37200 nM
Estimate against measurement, compound 4: 3.7-fold (0.57 log units) below; the measured number lies above the stated range.
By their numbers in this assay, from the lowest: compound 2; then compounds 3 and 1 (each within the scatter of the next); then compound 4.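

The aryl group on the amine nitrogen is not a silent part of the series in this assay: replacing 3-fluorophenyl with 4-carboxyphenyl gives a 4.0-fold higher number from compound 1 to compound 4 (0.60 log units; beyond the scatter). For the compounds shown here, this is the only measured change at this position, and its direction is towards a weaker inhibitor, so the position responds to at least this one replacement while the rest of the core of compound 1 stays the same. No measurement shown bears on the cause of this step.

Going by these compounds alone, the single step removes the fluorine and brings in the carboxylic acid together, so the contribution of each stays unresolved. Going by these compounds, whether a plain phenyl, a methyl ester or a primary amide on this nitrogen would stay near compound 1 or follow compound 4 remains open.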